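The source may report more compounds than this note shows. Statements on the series, on what has been measured and on what is new or still open speak of the compounds shown alone.

Measured so far:
- compound 1, `CCCCCCCCCCCSC[C@H](NC(C)=O)C(=O)CCl`: 1700 nM in a functional assay on NALM-6 cells (Homo sapiens); on this read-out higher numbers stand for weaker inhibition and lower numbers for stronger inhibition
- compound 2, `CCCCCCCCCCCCCCCSC[C@H](NC(C)=O)C(=O)CCl`: 8900 nM in this assay

For the measured compounds named here, compound 2 gives the higher of these two numbers, and its only neighbour is compound 1. Going by the values given here, the single measured step, a 5.2-fold higher number from compound 1 to compound 2 (0.72 log units; beyond the scatter), came from lengthening the saturated chain.

Compound 3, `CCCCCCCCCCCCCCCCCCSC[C@H](NC(C)=O)C(=O)CCl`, differs from compound 2 by propyl in place of hydrogen on a saturated chain carbon, ten or more bonds along the chain from a sulfur, the same kind of lengthening once more. Among the compounds with values here, with a 5.2-fold higher number from compound 1 to compound 2 (0.72 log units; beyond the scatter) as the only guide, a further weakening of roughly that size is expected. Compound 3 is therefore expected to give 27000 nM, within 9000 nM to 80000 nM, an expected step of a 3.0-fold higher number from compound 2 to compound 3 (0.48 log units; beyond the scatter).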

Compound 3, half-maximal inhibitory concentration: > 100000 nM
Compound 3 was reported as a limit; the forecaster's own chance of this, stated with the estimate: 25%; at least 3.7-fold (0.56 log units) between middle value and limit.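

Adding propyl at this saturated chain carbon gives an at least 11-fold higher number from compound 2 to compound 3 (1.05 log units; beyond the scatter), so the weakening seen with the earlier lengthening continues and does not level off. Across these three compounds, none goes against this trend, and the whole lengthening with heptyl amounts to an at least 58-fold higher number from compound 1 to compound 3 (1.76 log units; beyond the scatter). Compound 3 gives a limit and not a number, so the full size of both steps stays unknown: the limit of > 100000 nM in this assay, at which 1 of the 3 values shown sits.

On these data alone, whether a chain shorter than that of compound 1 gives stronger inhibition remains open. So does the effect of an amine or a carboxylic acid at this chain carbon.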